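A few compounds are considered here, and "the series" means these few. Any claim that something is new, unique, unknown or untested is made for them only; others in the source may bear on it.

Compound 1 `CCCn1c(=O)[nH]c2nc(-c3ccc(S(=O)(=O)N4CCN(C)CC4)cc3)[nH]c2c1=O`: > 1000 nM
Compound 2 `CCCn1c(=O)c2[nH]c(-c3ccc(S(=O)(=O)N4CCN(c5ccc(Cl)cc5)CC4)cc3)nc2n(C)c1=O`: > 1000 nM

In an assay on CHO cells for displacement of a labelled ligand from adenosine receptor A3 (Homo sapiens), read by scintillation counting, with a stated time of 45 min, in the presence of a further agent that is not named here (on this read-out higher numbers stand for weaker inhibition and lower numbers for stronger inhibition), compound 1 gives > 1000 nM, and this is a limit of the assay, not a measured number. Compound 2 likewise returns only a limit, > 1000 nM. Both results sit at the limit of > 1000 nM in this assay, at which 2 of the 2 values shown sit, so neither compound can be placed on a scale of strength, and nothing separates compound 1 from compound 2 on the numbers shown; compound 1 simply stands at the point beyond which the assay reports no value.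

Compound 3 `CCCn1c(=O)[nH]c2nc(-c3ccc(S(=O)(=O)N4CCN(Cc5ccc(Br)cc5)CC4)cc3)[nH]c2c1=O` has not yet been tested. It differs from compound 1 by 4-bromophenyl in place of hydrogen on a saturated chain carbon bound to an amine nitrogen in a ring. Among the measured compounds shown here, no step between two measured compounds is available here, so the size of the change in this assay cannot be read from the data; the only guide is that both measured compounds gave no number at all. The step that the limit leaves unreadable from compound 1 to compound 3 is therefore expected to be none beyond the scatter, with the risk of another limit. Compound 3 is estimated at 3000 nM, in a range from 700 nM to 20000 nM.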

Compound 3, inhibition constant: > 1000 nM
Compound 3 was reported as a limit; the forecaster's own chance of this, stated with the estimate: 70%; the middle value is on the limit's open side.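

In this assay compound 3 gives > 1000 nM, which is a limit and not a measured number. No size can be read for the change from compound 1 to compound 3, since every compound shown stops at the same point: the limit of > 1000 nM in this assay, at which 3 of the 3 values shown sit. The compounds shown leave open how strongly any of them inhibits, and whether 4-bromobenzyl in place of methyl changes that at all.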